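Chloro to methyl on the enone aryl: little change expected

This account rests on a few compounds, and the source may have more. Where it says the series, first, only, none or still open, it means among the compounds named here.

Compound 1 `COc1ccc(/C=C/C(=O)c2cc(-c3ccc(OC)c(OC)c3)n3nc(-c4ccccc4)cc3n2)cc1`: 50700 nM
Compound 2 `COc1ccc(-c2cc(C(=O)/C=C/c3ccc(Cl)cc3)nc3cc(-c4ccccc4)nn23)cc1OC`: 39100 nM

Of the compounds shown here, two have so far been tested in an ADME assay on HEK293 cells (Homo sapiens) for antiproliferative activity, read by MTT assay, with a stated time of 24 h; on this read-out higher numbers stand for weaker inhibition and lower numbers for stronger inhibition. Compound 1 gives 50700 nM, and compound 2 gives 39100 nM. Compound 2 thus holds the lower of the two numbers, but the step of a 1.3-fold lower number from compound 1 to compound 2 (0.11 log units; within the scatter) lies within the scatter, so on this read-out the two compounds cannot be told apart.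

Compound 3 `COc1ccc(-c2cc(C(=O)/C=C/c3ccc(C)cc3)nc3cc(-c4ccccc4)nn23)cc1OC` has not yet been measured. It differs from compound 2 by methyl in place of chloro on an aromatic carbon. Within the data shown here, the only measured step that touches this part of the molecule is the one from compound 1 to compound 2, where a chloro replaced a methoxy on an aromatic carbon and gave a 1.3-fold lower number from compound 1 to compound 2 (0.11 log units; within the scatter), a change within the scatter. Nothing is known here about a methyl in this place. On that basis, no step beyond the scatter is expected when chloro gives way to methyl in this assay. Compound 3 is therefore estimated at 40000 nM, within a range from 15000 nM to 110000 nM. The expected change is then a 1.0-fold higher number from compound 2 to compound 3 (0.01 log units; within the scatter).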

Compound 3, half-maximal inhibitory concentration: 57400 nM
Compound 3: middle estimate off by 1.4-fold (0.16 log units), on the low side; low and high end bracket the measured number.
By their numbers in this assay, from the lowest: compounds 2, 1 and 3 (each within the scatter of the next).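

In this assay, replacing the 4-chlorophenyl with the 4-methylphenyl gives a 1.5-fold higher number from compound 2 to compound 3 (0.17 log units; within the scatter) and, read against the methoxy compound, methyl in place of methoxy gives a 1.1-fold higher number from compound 1 to compound 3 (0.05 log units; within the scatter) at the same place on the ring, para to a large group. Before this result, only methoxy and chloro could be compared here; now three groups at this position, methoxy, chloro and methyl, give numbers that all lie within the scatter of one another, so this read-out does not separate any of the three compounds. No measurement available here explains why these three groups read alike.

As far as these compounds go, whether a different kind of group at this position, such as an amine, a carboxylic acid or a longer chain, would move the number beyond the scatter remains open. All three compounds also share the rest of the structure, so how a change to the shared core or to its other aromatic rings would read in this assay is likewise unanswered.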